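Swapping a benzyl amide for cyclohexyl on a shared core

This account rests on a few compounds, and the source may have more. Where it says the series, first, only, none or still open, it means among the compounds named here.

Of the compounds shown here, three built on one shared core have been tested in a functional assay on SK-BR-3 cells (Homo sapiens) for cytotoxicity, read by MTT assay, with a stated time of 72 h; a higher number here means a weaker inhibitor, a lower number a stronger inhibitor. Compound 1 `N[C@H]1CC[C@H](Nc2c(C(=O)NCc3ccc(F)cc3)nc(N3CCCCS3(=O)=O)c3cccnc23)CC1` gives 8500 nM. Compound 2 `COc1ccc(CNC(=O)c2nc(Br)c3cccnc3c2N[C@H]2CC[C@H](N)CC2)cc1` gives 5000 nM, and compound 3 `O=C(NCCCNc1c(C(=O)NCc2ccc(F)cc2)nc(Br)c2cccnc12)c1ccccc1` gives 1000 nM. Among these three numbers, compound 2 holds the second highest; its gap to compound 1 lies within the usual scatter, so no order can be read between those two, while its gap to compound 3 lies beyond the scatter, with compound 3 showing the lower number.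

Compound 4 `N[C@H]1CC[C@H](Nc2c(C(=O)NC3CCCCC3)nc(Br)c3cccnc23)CC1` has not yet been measured. It differs from compound 2 in one place: cyclohexyl in place of 4-methoxybenzyl on an amide-type nitrogen. Within the data shown here, no pair of measured compounds differs in exactly this way, so there is no measured step to lean on. Without such a reference, the expectation is a step that stays within the scatter, a 1.3-fold lower number from compound 2 to compound 4 (0.10 log units; within the scatter). Compound 4 is therefore expected to give about 4000 nM, with a range from 1200 nM to 12000 nM.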

Compound 4, half-maximal inhibitory concentration: 4200 nM
Compound 4: middle estimate off by 1.1-fold (0.02 log units), on the low side, within the range that was stated.
By their numbers in this assay, from the lowest: compound 3; then compounds 4, 2 and 1 (each within the scatter of the next, the first and the last beyond it).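

Among these compounds, this is the first measured step at this position. Putting cyclohexyl in place of 4-methoxybenzyl on the amide-type nitrogen gives a 1.2-fold lower number from compound 2 to compound 4 (0.08 log units; within the scatter) in this assay, so this pair cannot be told apart in this assay. The swap removes the aromatic ring and the methoxy oxygen of the leaving group, yet the read-out stays within the scatter, which shows that neither feature is needed here to keep a number of this size, at least on the core shared by this pair. Nothing available explains why the two numbers lie so close.

Still open, from the compounds shown here alone, is whether a much smaller group such as methyl, or a chain ending in an amine or a carboxylic acid, would also stay within the scatter on this nitrogen. Going by these compounds, it is also open whether the same swap would give a similar step with a different group on the other positions of the core.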